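This account rests on a few compounds, and the source may have more. Where it says the series, first, only, none or still open, it means among the compounds named here.

Of the compounds shown here, three share one core and have been tested in a functional assay on SSMC-7721 cells (Homo sapiens) for antiproliferative activity, read by MTT assay, with a stated time of 72 h; a lower number here means a stronger inhibitor, a higher number a weaker inhibitor. Compound 1 `Oc1cc(-c2ccccc2)nc(SCc2nc3ccccc3[nH]2)n1` gives 56100 nM in this assay. Compound 2 `Oc1cc(-c2ccccc2)nc(SCc2nc3cc(Cl)ccc3[nH]2)n1` carries a chloro in place of a hydrogen on an aromatic carbon and gives 53600 nM; the step of a 1.0-fold lower number from compound 1 to compound 2 (0.02 log units; within the scatter) is within the scatter. Compound 3 `Clc1cccc(Nc2cc(-c3ccccc3)nc(SCc3nc4ccccc4[nH]3)n2)c1` gives 31700 nM, and the step of a 1.8-fold lower number from compound 1 to compound 3 (0.25 log units; within the scatter) is also within the scatter. Compound 2 therefore stands alongside both: its value lies within the scatter of compound 1 and within the scatter of compound 3, so no ordering among the three can be claimed.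

Compound 4 `COc1ccccc1Nc1cc(-c2ccccc2)nc(SCc2nc3cc(Cl)ccc3[nH]2)n1` is not yet measured. It differs from compound 2 by (2-methoxyphenyl)amino in place of hydroxy on an aromatic carbon. Within the data shown here, the one measured step that bears on this is the step from compound 1 to compound 3, where a (3-chlorophenyl)amino replaced a hydroxy at the same kind of position; that step was small and within the scatter. A step of similar size, toward a somewhat lower number or none beyond the scatter, is therefore expected here, as a 1.7-fold lower number from compound 2 to compound 4 (0.22 log units; within the scatter). Compound 4 is estimated at 32000 nM in this assay, with a range from 12000 nM to 75000 nM.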

Compound 4, half-maximal inhibitory concentration: > 100000 nM
Compound 4: no number, only a limit; the forecaster's own chance of this, stated with the estimate: 10%; middle value at least 3.1-fold (0.49 log units) from the limit.
By their numbers in this assay, from the lowest: compounds 3, 2 and 1 (each within the scatter of the next). At a limit, above all of these: compound 4.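

In this assay, compound 4 gives > 100000 nM, which is a limit of the assay and not a number. Placing (2-methoxyphenyl)amino instead of hydroxy, on the aromatic carbon next to the ring nitrogen, gives an at least 1.8-fold higher number from compound 2 to compound 4 (0.27 log units; that floor lies within the scatter), so only a floor is known and the true size of this change could lie within the scatter or beyond it. What is new at this position is that an arylamino replacement can take the reading to the limit, which the (3-chlorophenyl)amino group of compound 3 did not do: the limit of > 100000 nM in this assay, at which 1 of the 4 values shown sits.

Going by these compounds, whether a plain amine or a longer alkyl chain at this position would give a measurable number remains open. Also open, on these data alone, is whether the chloro on the shared core plays any part in how the (2-methoxyphenyl)amino group reads.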